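Second ring fluorine on the aryl of compound 2

The source may report more compounds than this note shows. Statements on the series, on what has been measured and on what is new or still open speak of the compounds shown alone.

Among the measured compounds shown here, compound 2 `COc1ccc(F)cc1C1CCN(c2ccn3c(CC4CC4)nnc3c2Cl)CC1` sits lowest of the two values measured so far in a functional assay on CHO cells for agonist activity at metabotropic glutamate receptor 2 (Homo sapiens), read by scintillation counting and GTPgammaS binding, with a stated time of 30 min; a higher number here means a larger maximal response, a lower number a smaller maximal response: compound 2 gives 283%, while compound 1 `COc1ccc(F)cc1C1CCN(c2ccn3c(CC(F)(F)F)nnc3c2Cl)CC1` gives 340%. For the measured compounds named here, the only step measured is a number 57 percentage points lower from compound 1 to compound 2 (beyond the scatter), for cyclopropyl in place of trifluoromethyl on a saturated chain carbon bound to an aromatic carbon. Compound 3 `COc1ccc(F)c(F)c1C1CCN(c2ccn3c(CC4CC4)nnc3c2Cl)CC1` differs from compound 2 as follows: fluoro in place of hydrogen on an aromatic carbon; cut one bond further out, the change reads 5-fluoro-2-methoxyphenyl to 2,3-difluoro-6-methoxyphenyl. Going by the values given here, no measured pair touches this aromatic ring; the one known step concerns another part of the shared core and gives no direction for the added fluoro. Among the compounds with values here, with no comparable step, nothing beyond the scatter is expected in this assay, and the expected step is no change at the digits printed from compound 2 to compound 3 (within the scatter). Compound 3 is accordingly estimated at 283%, within 200% to 360%.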

Compound 3, largest response reached (Emax), in percent of the reference or control that the assay uses: 258%
Beside the measured number, compound 3's estimate is 25 percentage points above it; the range from low to high includes it.
By their numbers in this assay, from the lowest: compound 3; then compound 2; then compound 1.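

In this assay, the aromatic ring now has its first measured step: fluoro in place of hydrogen, on the aromatic carbon ortho to a fluoro group and ortho to a large group, gives a number 25 percentage points lower from compound 2 to compound 3 (beyond the scatter). The earlier pair concerned only the side chain, with a number 57 percentage points lower from compound 1 to compound 2 (beyond the scatter), so the maximal response is now shown to respond to changes in both places, and compound 3 still gives 258% with the 2,3-difluoro-6-methoxyphenyl group. Nothing available explains the drop at this carbon.

Open, going by these compounds, is whether a chloro or a methyl group on this carbon would shift the response in the same direction. Also open, on these data alone, is whether the fluoro step carries over to the trifluoromethyl side chain of compound 1.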